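This account rests on a few compounds, and the source may have more. Where it says the series, first, only, none or still open, it means among the compounds named here.

Compound 1 `Nc1scc(CN2CCN(c3cc(Cl)cc(Cl)c3)CC2)c1C(=O)c1ccc(Cl)cc1` and compound 2 `Nc1scc(CN2CCN(c3cccc(F)c3)CC2)c1C(=O)c1ccc(Cl)cc1` share one core and differ only in the group carried on an amine nitrogen in a ring. In an assay on CHO cells for displacement of a labelled ligand from adenosine receptor A1 (Homo sapiens), read by scintillation counting, with a stated time of 120 min, tested at 10 uM (on this read-out higher numbers stand for more inhibition at the one concentration tested (going by the name of the read-out) and lower numbers for less inhibition), compound 1 gives 1%, and compound 2 gives 1%. The step of no change at the digits printed from compound 1 to compound 2 (within the scatter) shows that putting 3-fluorophenyl in place of 3,5-dichlorophenyl at that position left the read-out flat, so compound 2 stands level with compound 1, both at the low end of the scale. Compound 3 `Nc1scc(CN2CCN(CCCc3ccc(Cl)cc3)CC2)c1C(=O)c1ccc(Cl)cc1` differs from compound 2 in a single place: 3-(4-chlorophenyl)propyl in place of 3-fluorophenyl on an amine nitrogen in a ring. Among the measured compounds shown here, the only measured step that bears on this change, no change at the digits printed from compound 1 to compound 2 (within the scatter), was within the scatter, and it concerned the same ring nitrogen, so the group carried there has so far not moved the signal at all. The expected step of a number 4 percentage points higher from compound 2 to compound 3 (within the scatter) is therefore none beyond the scatter. Compound 3 is estimated at 5%, within a range from 0% to 25%.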

Compound 3, a percentage reported as inhibition, at one concentration (the size of the read-out at that concentration, not a potency): 0%
The estimate for compound 3 lay 5 percentage points above the measured number, within the range that was stated.
By their numbers in this assay, from the lowest: compounds 3, 1 and 2 (each within the scatter of the next).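

Among the compounds shown here, earlier, the only comparison at this ring nitrogen was between two substituted phenyl groups. Moving to 3-(4-chlorophenyl)propyl, with 10 heavy atoms in place of the 7 in 3-fluorophenyl and a propyl chain carrying the aromatic ring, gives a number 1 percentage points lower from compound 2 to compound 3 (within the scatter) in this assay, and the comparison with the dichlorinated group gives a number 1 percentage points lower from compound 1 to compound 3 (within the scatter), so even this larger change of shape leaves the signal at the low end of the scale. Nothing available explains why the read-out stays this low.

As far as these compounds go, all three compounds share one core, so it remains open whether any group on this nitrogen could raise the signal, or whether the rest of the molecule keeps it low. A carboxylic acid or a primary amine at the end of the propyl chain would test this position with a group of a different kind.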